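The source may report more compounds than this note shows. Statements on the series, on what has been measured and on what is new or still open speak of the compounds shown alone.

Measured so far in a functional assay on LS174T cells (Homo sapiens) for antiproliferative activity; a lower number here means a stronger inhibitor, a higher number a weaker inhibitor:
Compound 1 `CN(C)c1ncc(/C=C/c2c(F)cccc2F)cn1`: > 200 nM, a limit.
Compound 2 `CNc1ncc(/C=C/c2c(F)cccc2F)cn1`: > 200 nM, a limit.

Compound 2 therefore has no number, only the limit > 200 nM. The measured values share one position: the limit of > 200 nM in this assay, at which 2 of the 2 values shown sit. The next compound, compound 3 `CCNc1ncc(/C=C/c2c(F)cccc2F)cn1`, differs from compound 2 by methyl in place of hydrogen on a saturated chain carbon bound to a nitrogen on an aromatic ring. In words, this is methyl in place of hydrogen on a saturated chain carbon bound to a nitrogen on an aromatic ring, so methylamino becomes ethylamino. Among the measured compounds shown here, since the one measured step bearing on this is a step that the two limits leave unreadable from compound 1 to compound 2, neither a size nor a direction carries over, and no change beyond the scatter is expected in this assay. The expected step is a step that the limit leaves unreadable from compound 2 to compound 3. Compound 3 is estimated at 300 nM, with an expected range from 100 nM to 1000 nM.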

Compound 3, half-maximal inhibitory concentration: > 200 nM
Compound 3: only a limit was reported; the forecaster's own chance of this, stated with the estimate: 70%; the middle value lies beyond the limit too.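

In this assay, among the compounds shown here, compound 3 is reported only as a limit, so no step to it from compound 1 or compound 2 can be read, and all three compounds share one position: the limit of > 200 nM in this assay, at which 3 of the 3 values shown sit. On these data alone, how far each compound lies beyond that limit remains open.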